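From 2-hydroxypropoxy to 2-methoxyethoxy on a shared core

A few compounds are considered here, and "the series" means these few. Any claim that something is new, unique, unknown or untested is made for them only; others in the source may bear on it.

In a functional assay on DU-145 cells (Homo sapiens) for cytotoxicity, read by MTT assay (on this read-out lower numbers stand for stronger inhibition and higher numbers for weaker inhibition), compound 1 `CC(C)=CC[C@@H](OC[C@H](C)O)C1=CC(=O)c2c(O)ccc(O)c2C1=O` gives 24500 nM and compound 2 `CC(C)=CC[C@@H](OC[C@@H](C)O)C1=CC(=O)c2c(O)ccc(O)c2C1=O` gives 14300 nM, so compound 2 stands level with compound 1 within the scatter. Among the compounds with values here, the one measured step, a 1.7-fold lower number from compound 1 to compound 2 (0.23 log units; within the scatter), comes with the fact that compounds 1 and 2 differ only in the configuration as drawn, so it says nothing direct about a new side chain. Compound 3 `COCCO[C@H](CC=C(C)C)C1=CC(=O)c2c(O)ccc(O)c2C1=O` differs from compound 2 by methoxymethyl in place of 1-hydroxyethyl on a saturated chain carbon bound to an oxygen on a saturated carbon: methoxymethyl in place of 1-hydroxyethyl. Within the data shown here, with no measured step for such a swap, no shift beyond the scatter is expected, and the expected step is a 1.1-fold higher number from compound 2 to compound 3 (0.05 log units; within the scatter). Compound 3 is estimated at 16000 nM, with an expected range of 7000 nM to 40000 nM.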

Compound 3, half-maximal inhibitory concentration: 43200 nM
The estimate for compound 3 lay 2.7-fold (0.43 log units) below the measured number; the whole stated range lies below it.
By their numbers in this assay, from the lowest: compounds 2, 1 and 3 (each within the scatter of the next, the first and the last beyond it).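

In this assay, within the data shown here, methoxymethyl in place of 1-hydroxyethyl on a saturated chain carbon bound to an oxygen on a saturated carbon gives the first step beyond the scatter: a 3.0-fold higher number from compound 2 to compound 3 (0.48 log units; beyond the scatter). Starting from the other configuration, the same swap gives a 1.8-fold higher number from compound 1 to compound 3 (0.25 log units; within the scatter), so its apparent size depends on the starting compound, and those two starting compounds are closely related: the fact that compounds 1 and 2 differ only in the configuration as drawn. Neither step gives a lower number.

As far as these compounds go, whether losing the hydrogen-bond donor of 1-hydroxyethyl matters remains open. So does how an amine or a longer chain would read here.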